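The source may hold more compounds than are shown below. What is called first, only, known or untested is meant among the compounds shown, and "the series" means these compounds.

Measured so far:
compound 1 `CCOC(=O)c1cccc(-c2n[nH]c3ccccc23)c1`, 5650 nM
compound 2 `CCOC(=O)c1ccc(-c2nn(Cc3ccccc3F)c3ccccc23)cc1`, 110 nM
compound 3 `CCOC(=O)c1cccc(-c2nn(Cc3ccccc3)c3ccccc23)c1`, > 10000 nM

In a functional assay on cells (Platelet, Homo sapiens) for inhibition (a higher number here means a weaker inhibitor, a lower number a stronger inhibitor), compound 2 stands lowest of the two numbers; compound 1 gives a number far higher. Compound 3 gives only a limit of the assay (the limit of > 10000 nM in this assay, at which 1 of the 3 values shown sits). Going by the values given here, the one measured step on this aromatic nitrogen, an at least 1.7-fold higher number from compound 1 to compound 3 (0.24 log units; that floor lies within the scatter), comes from a benzyl in place of hydrogen and is unlike the change here. Compound 4 `CCOC(=O)c1ccc(-c2nn(-c3ccco3)c3ccccc23)cc1` differs from compound 2 as follows: furan-2-yl in place of 2-fluorobenzyl on an aromatic nitrogen. Among the compounds with values here, no measured step compares two groups on this nitrogen, so little can be said about direction, and a moderate loss is expected, a 4.5-fold higher number from compound 2 to compound 4 (0.66 log units; beyond the scatter). Compound 4 is estimated at 500 nM, between 100 nM and 3000 nM.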

Compound 4, half-maximal inhibitory concentration: 340 nM
Compound 4: the middle estimate sits 1.5-fold (0.17 log units) above what was measured; the range from low to high includes it.
By their numbers in this assay, from the lowest: compound 2; then compound 4; then compound 1. At a limit, above all of these: compound 3.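

In this assay, going by these compounds alone, the step of a 3.1-fold higher number from compound 2 to compound 4 (0.49 log units; beyond the scatter) is the first direct comparison of two groups on this aromatic nitrogen. It shows that 2-fluorobenzyl can give way to the smaller furan-2-yl at only a modest cost, so this position accepts more than one aromatic group. On these data alone, it remains open how an aminoethyl chain or a simple methyl group would fare on this nitrogen, and whether a carboxylic acid in place of the ethyl ester would change the picture. Nothing shown here gives a cause for this step.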